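Benzimidazole in place of the hydroxyphenyl imine on a coumarin

A few compounds are considered here, and "the series" means these few. Any claim that something is new, unique, unknown or untested is made for them only; others in the source may bear on it.

Measured compounds:
compound 1, `O=c1cc(/C=N\c2ccc(O)cc2)c2ccc(OCc3ccccc3)cc2o1` — 233000 nM
compound 2, `O=c1cc(/C=N\O)c2c(OCc3ccccc3)cc(OCc3ccccc3)cc2o1` — "not active" (no number reported)
compound 3, `N/N=C\c1cc(=O)oc2cc(OCc3ccccc3)cc(OCc3ccccc3)c12` — > 2000000 nM

Among the compounds with values here, in a functional assay, read by spectrophotometry, with a stated time of 1 h (a higher number here means a weaker inhibitor, a lower number a stronger inhibitor), compound 1 gives 233000 nM, the only plain number among the three results. Compound 2 is reported as "not active" (no number reported). For compound 3 the result is a limit of the assay, > 2000000 nM, which is the limit of > 2000000 nM in this assay, at which 1 of the 3 values shown sits. No pair of these compounds differs in one place, so no measured step is available.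

Compound 4, `O=c1cc(-c2nc3ccccc3[nH]2)c2ccc(OCc3ccccc3)cc2o1`, arises from compound 1 by a group of 9 heavy atoms (7 carbon, 2 nitrogen; one five-membered aromatic ring with 2 hetero atoms, one six-membered aromatic ring of carbon only) in place of a group of 9 heavy atoms (7 carbon, 1 nitrogen, 1 oxygen; one six-membered aromatic ring of carbon only), on an aromatic carbon. Without a comparable measured step, the writer expects a change of modest size, if any, with the direction open. Compound 4 is therefore estimated at 150000 nM, between 30000 nM and 800000 nM, a step of a 1.6-fold lower number from compound 1 to compound 4 (0.19 log units; within the scatter) that is expected to stay close to the scatter.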

Compound 4, half-maximal inhibitory concentration: "not active" (no number reported)
Compound 4 has no reported number here, so the estimate cannot be set against anything.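

Compound 4 is reported as "not active" without a number, so no step from compound 1 to compound 4 can be read, and nothing shown bears on this result. The compounds shown leave open how far the 1H-benzimidazol-2-yl group shifts the read-out in this assay.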